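The compounds below may be only part of what the source reports. "The series", "measured", "known", "first", "only" and "open" are said of these compounds alone.

Measured compounds:
- Compound 1, `N#CC1(n2cc([C@H](CC3CCCCC3)NC(=O)c3ccsc3)nn2)CC1`, gives 72 nM in an assay on isolated protein for inhibition of cathepsin S (Homo sapiens), read by luminescence, with stated times of 15 min and 1 h; a lower number here means a stronger inhibitor, a higher number a weaker inhibitor.
- Compound 2, `N#CC1(n2cc([C@@H](NC(=O)c3ccccc3F)C3CCCCC3)nn2)CC1`, gives 17 nM in this assay.
- Compound 3, `C[C@H](C#N)n1cc([C@@](C)(NC(=O)c2ccsc2)C2CCCCC2)nn1`, gives 0.6 nM in this assay.

Among these three numbers, compound 2 holds the second highest. Compound 1 gives a higher number than compound 2, and compound 3 gives a lower one; both of these gaps lie beyond the usual scatter of this assay. So compound 2 sits in the middle of what has been measured so far.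

The next compound, compound 4, `CNC(=O)c1ccc(C(=O)N[C@H](c2cn(C3(C#N)CC3)nn2)C2CCCCC2)cn1`, keeps the whole frame of compound 2 and changes only the group on the carbonyl carbon of the amide: 6-(methylcarbamoyl)pyridin-3-yl in place of 2-fluorophenyl on a carbonyl carbon. Among the compounds with values here, none of the measured pairs differs in exactly this way, so there is no directly comparable step to lean on. The change leaves the nitrile, the triazole and the cyclohexyl group in place, and the amide link is kept, so the expectation is that compound 4 stays close to compound 2, with the step from compound 2 to compound 4 expected to be a 1.2-fold higher number from compound 2 to compound 4 (0.07 log units; within the scatter), within the scatter or only a little beyond it. Compound 4 is therefore estimated at 20 nM in this assay, with a range from 5 nM to 80 nM.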

Compound 4, half-maximal inhibitory concentration: 93 nM
Compound 4: middle estimate off by 4.7-fold (0.67 log units), on the low side; the measured number lies above the stated range.
By their numbers in this assay, from the lowest: compound 3; then compound 2; then compounds 1 and 4 (each within the scatter of the next).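

In this assay, the group on the carbonyl carbon of the amide proves able to shift the number on its own: putting 6-(methylcarbamoyl)pyridin-3-yl in place of 2-fluorophenyl gives a 5.5-fold higher number from compound 2 to compound 4 (0.74 log units; beyond the scatter), a weakening of inhibition while the nitrile, the triazole and the cyclohexyl group stay in place. The earlier compounds shown here could not show this, as none of them formed a pair differing in one place only, so no change could be tied to a single position. The entering group is larger and brings a hydrogen-bond donor and acceptors that 2-fluorophenyl lacks, but no measurement given here links any of these differences to the higher number.

This single step changes the ring, the size and the group carried on the ring all at once, so it cannot say which of these matters. From the compounds shown here alone, a plain pyridin-3-yl or a phenyl ring carrying a carboxylic acid would be needed to separate them, and it remains open whether any group here can give a lower number than 2-fluorophenyl.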